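Compound 4: a 4-methylpiperazin-1-yl swap on compound 1

The source may report more compounds than this note shows. Statements on the series, on what has been measured and on what is new or still open speak of the compounds shown alone.

For the measured compounds named here, in a functional assay on MCF7 cells (Homo sapiens) for cytotoxicity, read by MTT assay, with a stated time of 72 h (on this read-out lower numbers stand for stronger inhibition and higher numbers for weaker inhibition), compound 1 (`COc1ncc(-c2ccc3nc(NC(=O)NCCN4CCCCC4)nn3c2)cc1NS(=O)(=O)c1ccc(F)cc1`) gives 200 nM and holds the lowest of the three numbers so far. Compound 3 (`CCN(CC)CCNC(=O)Nc1nc2ccc(-c3cnc(OC)c(NS(=O)(=O)c4ccc(F)cc4F)c3)cn2n1`) reads 740 nM on the same read-out, and compound 2 (`COc1ncc(-c2ccc3nc(NC(=O)NCC(=O)N4CCCC4)nn3c2)cc1NS(=O)(=O)c1ccc(F)cc1`) reads 2130 nM there. Compound 4 (`COc1ncc(-c2ccc3nc(NC(=O)NCCN4CCN(C)CC4)nn3c2)cc1NS(=O)(=O)c1ccc(F)cc1`) has not yet been measured. It carries 4-methylpiperazin-1-yl in place of piperidin-1-yl on a saturated chain carbon, two bonds along the chain from an amide-type nitrogen. Going by the values given here, one measured step touches the same chain (an 11-fold higher number from compound 1 to compound 2 (1.03 log units; beyond the scatter)). That step is large, so the number can respond to changes there, but it replaces (piperidin-1-yl)methyl with (pyrrolidin-1-yl)carbonyl, which is a different kind of change. Among the compounds with values here, no measured step shows the present swap. No step beyond the scatter is expected, only perhaps a slight rise in the number (a 1.5-fold higher number from compound 1 to compound 4 (0.18 log units; within the scatter)). The estimate for compound 4 is 300 nM in this assay with an expected range from 100 nM up to 900 nM on this read-out.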

Compound 4, half-maximal inhibitory concentration: 500 nM
For compound 4 the middle estimate is 1.7-fold (0.22 log units) below the measured one, within the range that was stated.
By their numbers in this assay, from the lowest: compound 1; then compounds 4 and 3 (each within the scatter of the next); then compound 2.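

In this assay, the 4-methylpiperazin-1-yl in place of piperidin-1-yl on a saturated chain carbon, two bonds along the chain from an amide-type nitrogen, gives a 2.5-fold higher number from compound 1 to compound 4 (0.40 log units; beyond the scatter). The number at this position therefore responds even to a swap between two six-membered non-aromatic rings, while the change from (pyrrolidin-1-yl)carbonyl to (4-methylpiperazin-1-yl)methyl gives a 4.3-fold lower number from compound 2 to compound 4 (0.63 log units; beyond the scatter), so compound 2 stays above both (piperidin-1-yl)methyl and (4-methylpiperazin-1-yl)methyl compounds. No supporting measurement is available to explain either step.

The compounds shown leave open where morpholin-4-yl or a dimethylamino group on the same chain would fall in relation to compound 1 and compound 4. They also leave open how a longer chain carrying piperidin-1-yl would read.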